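The source may report more compounds than this note shows. Statements on the series, on what has been measured and on what is new or still open speak of the compounds shown alone.

Measured so far:
compound 1, `CCCc1cc(=O)n([C@@H]2O[C@H](COP(=O)(O)OP(=O)(O)O)[C@@H](O)[C@H]2O)c(=O)[nH]1`: in an in vitro functional assay on 1321-N1 cells for agonist activity at P2Y purinoceptor 4 (Homo sapiens) (on this read-out higher numbers stand for an effect only at larger amounts of compound and lower numbers for an effect already at smaller amounts), compound 1 gives > 100000 nM, and this is a limit of the assay, not a number.
compound 2, `Cc1cc(=O)n([C@@H]2O[C@H](COP(=O)(O)O)[C@@H](O)[C@H]2O)c(=O)[nH]1`: in this assay compound 2 gives > 100000 nM, again a limit of the assay rather than a number.

Among the measured compounds shown here, compound 2 therefore stands where every value shown stands, at the limit of > 100000 nM in this assay, at which 2 of the 2 values shown sit; no compound here has been given a measured number in this assay.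

Compound 3, `CCCc1cc(=O)n([C@@H]2O[C@H](COP(=O)(O)O)[C@@H](O)[C@H]2O)c(=O)[nH]1`, differs from compound 2 in one place: ethyl in place of hydrogen on a saturated chain carbon bound to an aromatic carbon. For the measured compounds named here, because no pair of measured compounds differs in a single place, there is no measured step to lean on. What can be said is that compound 1, which already carries the propyl chain, also sits at the limit in this assay, as does compound 2 with its methyl. The expectation is therefore a step of a number no higher from compound 2 to compound 3 (the limit leaves the size open), that is, no movement beyond the scatter. Compound 3 is expected to give about 100000 nM, within 30000 nM to 300000 nM, and most likely to be reported only as a limit again.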

Compound 3, half-maximal effective concentration: > 100000 nM
Compound 3 was reported as a limit; the forecaster's own chance of this, stated with the estimate: 85%; the middle value sits exactly at the limit.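

Among the compounds shown here, compound 1, compound 2 and compound 3 each give only a limit of the assay in this assay, so no step among them can be read: the limit of > 100000 nM in this assay, at which 3 of the 3 values shown sit.

The compounds shown leave open whether swapping methyl for propyl changes the effect at all, since none has a measured number here.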